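The source may hold more compounds than are shown below. What is called first, only, known or untested is meant among the compounds shown, and "the series" means these compounds.

Measured so far in a functional assay on SNB-19 cells (Homo sapiens) for inhibition, read by MTT assay, with a stated time of 7 days; on this read-out higher numbers stand for weaker inhibition of growth and lower numbers for stronger inhibition of growth:
- compound 1 `NC(=O)c1ncn2c(=O)n(Cc3ccccc3)nnc12` gives > 50000 nM
- compound 2 `C[C@H](c1ccccc1)n1nnc2c(C(N)=O)ncn2c1=O` gives 32700 nM
- compound 3 `C[C@@H](c1ccccc1)n1nnc2c(C(N)=O)ncn2c1=O` gives 34700 nM

The entry for compound 1 is a limit and not a number.

Compound 3 stands at 34700 nM and cannot be told apart from compound 2 on these data. The pair shows a 1.1-fold higher number from compound 2 to compound 3 (0.03 log units; within the scatter), and the fact that compounds 2 and 3 differ only in the configuration as drawn therefore comes with no difference beyond the scatter.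

Compound 4 `CC[C@@H](c1ccccc1)n1nnc2c(C(N)=O)ncn2c1=O` carries the change (methyl in place of hydrogen on a saturated chain carbon, two bonds along the chain from an aromatic carbon and an aromatic nitrogen). This is methyl in place of hydrogen on a saturated chain carbon, two bonds along the chain from an aromatic carbon and an aromatic nitrogen, which also reads as methyl to ethyl.

Going by the values given here, no measured step covers this carbon. The nearest are the methyl-for-hydrogen steps on the saturated chain carbon bound to an aromatic carbon and an aromatic nitrogen, which show an at least 1.5-fold lower number from compound 1 to compound 2 (0.18 log units; that floor lies within the scatter) and an at least 1.4-fold lower number from compound 1 to compound 3 (0.15 log units; that floor lies within the scatter). From the compounds shown here alone, both are floors set by a limit, so their true size is unknown.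

In this assay, no step beyond the scatter is therefore expected, and the estimated step is a 1.2-fold lower number from compound 3 to compound 4 (0.06 log units; within the scatter). For compound 4 the expected value is 30000 nM, within an estimated range of 14000 nM to 60000 nM.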

Compound 4, concentration for 50% growth inhibition: > 50000 nM
Compound 4: only a limit was reported; the forecaster's own chance of this, stated with the estimate: 20%; middle value at least 1.6-fold (0.22 log units) from the limit.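

In this assay compound 4 gives > 50000 nM, which is a limit of the assay and not a number. Going by these compounds alone, this is the first reading for a change on the saturated chain carbon two bonds along the chain from an aromatic carbon and an aromatic nitrogen: methyl to ethyl gives an at least 1.4-fold higher number from compound 3 to compound 4 (0.15 log units; that floor lies within the scatter), so no gain in inhibition of growth is seen, and the true size of the step stays unknown. Methyl in place of hydrogen now carries opposite signs at the two chain positions, but only as floors, so the two steps cannot be compared in size: the same change on two cores in this assay, an at least 1.5-fold lower number (0.18 log units; that floor lies within the scatter) from compound 1 to compound 2 and an at least 1.4-fold higher number (0.15 log units; that floor lies within the scatter) from compound 3 to compound 4; the limit leaves it open whether they differ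

The step from compound 1 to compound 4 cannot be read, as both entries are limits. Still open, from the compounds shown here alone, are whether the opposite configuration of compound 4 would read the same, as the pair of compound 2 and compound 3 does within the scatter, and how a propyl chain, a hydroxyl or an amine would read on this saturated chain carbon.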